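The source may hold more compounds than are shown below. What is called first, only, known or untested is meant among the compounds shown, and "the series" means these compounds.

In a functional assay on A549 cells (Homo sapiens) for antiproliferative activity, read by MTT assay, with a stated time of 72 h (on this read-out lower numbers stand for stronger inhibition and higher numbers for weaker inhibition), compound 1 `COc1ccc(-c2noc(CCCCCCC(=O)NO)n2)cc1` gives 13500 nM and compound 2 `O=C(CCCCCCc1nc(-c2ccc(F)cc2)no1)NO` gives 5770 nM, while compound 3 `COc1ccc(-c2noc(CCCCCCC(=O)C(F)(F)F)n2)cc1` gives 35900 nM as the highest of the three numbers. Compound 4 `O=C(CCCCCCc1nc(-c2ccc(F)cc2)no1)C(F)(F)F` is still unmeasured. It carries fluoro in place of methoxy on an aromatic carbon relative to compound 3, a change set out as fluoro in place of methoxy on an aromatic carbon with the rest of the structure shared. The same swap has been measured once, as a 2.3-fold lower number from compound 1 to compound 2 (0.37 log units; beyond the scatter) and that modest step bears most directly on the question. The other measured step, a 2.7-fold higher number from compound 1 to compound 3 (0.42 log units; beyond the scatter) is also modest, but it concerns trifluoromethyl in place of hydroxyamino on a carbonyl carbon and so only links the two carbonyl ends. With a single precedent, and that one at the hydroxyamino end, a modest fall is expected, though a step within the scatter cannot be excluded. The expected step is a 2.3-fold lower number from compound 3 to compound 4 (0.36 log units; beyond the scatter) on this estimate. For compound 4 the estimated value is 15500 nM with an expected range from 6500 nM to 37000 nM in this assay for now.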

Compound 4, half-maximal inhibitory concentration: > 100000 nM
Compound 4 was reported as a limit (the forecaster's own chance of this, stated with the estimate: 10%); at least 6.4-fold (0.80 log units) between middle value and limit.
By their numbers in this assay, from the lowest: compound 2; then compound 1; then compound 3. At a limit, above all of these: compound 4.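

In this assay compound 4 is reported only as a limit, > 100000 nM. With trifluoromethyl on the carbonyl carbon, fluoro in place of methoxy gives an at least 2.7-fold higher number from compound 3 to compound 4 (0.44 log units; beyond the scatter), so the change from 4-methoxyphenyl to 4-fluorophenyl does not run the same way on both cores: the same change on two cores in this assay, a 2.3-fold lower number (0.37 log units; beyond the scatter) from compound 1 to compound 2 and an at least 2.7-fold higher number (0.44 log units; beyond the scatter) from compound 3 to compound 4, at least 6.5-fold (0.81 log units) apart, beyond the scatter of two such steps Read the other way, trifluoromethyl in place of hydroxyamino on a carbonyl carbon gives an at least 17-fold higher number from compound 2 to compound 4 (1.23 log units; beyond the scatter), so this change depends on the aromatic group it is paired with: the same change on two cores in this assay, a 2.7-fold higher number (0.42 log units; beyond the scatter) from compound 1 to compound 3 and an at least 17-fold higher number (1.23 log units; beyond the scatter) from compound 2 to compound 4, at least 6.5-fold (0.81 log units) apart, beyond the scatter of two such steps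

The limit leaves the full size of both new steps open, and the compounds shown do not say what lies behind the reversal. Going by these compounds, whether an amine or a chloro on the same aromatic carbon would follow the methoxy or the fluoro pattern also remains open.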